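A few compounds are considered here, and "the series" means these few. Any claim that something is new, unique, unknown or untested is made for them only; others in the source may bear on it.

Going by the values given here, in a functional assay on RS4-11 cells (Homo sapiens) for inhibition, read by CCK-8 assay, with a stated time of 48 h (a higher number here means a weaker inhibitor, a lower number a stronger inhibitor), three compounds have values so far. Compound 1 (`O=C(NCCNS(=O)(=O)c1sccc1-c1ccccc1Oc1ccc(O)c(O)c1)Nc1cc(Cl)cc(Cl)c1`) gives 6200 nM, compound 2 (`COc1ccc(Oc2ccc(C(C)C)cc2-c2ccsc2S(=O)(=O)NCCNC(=O)Nc2cc(Cl)cc(Cl)c2)cc1OC`) gives 9000 nM and compound 3 (`CC(C)c1ccc(Oc2ccc(O)c(O)c2)c(-c2ccsc2S(=O)(=O)NCCNC(=S)Nc2ccc([N+](=O)[O-])cc2)c1`) gives 5100 nM. Compound 3 thus stands within the scatter of both others. Compound 4 (`CC(C)c1ccc(Oc2ccc(O)c(O)c2)c(-c2ccsc2S(=O)(=O)NCCNC(=O)Nc2cc(Cl)cc(Cl)c2)c1`) has not yet been measured. It departs from compound 3 in one place, on an amine nitrogen: a group of 11 heavy atoms (7 carbon, 1 nitrogen, 1 oxygen, 2 chlorine; one six-membered aromatic ring of carbon only) in place of a group of 12 heavy atoms (7 carbon, 2 nitrogen, 2 oxygen, 1 sulfur; one six-membered aromatic ring of carbon only), on an amine nitrogen. No measured step sizes this change directly. No shift beyond the scatter is expected in this assay, because compound 1 at 6200 nM, which also carries the (3,5-dichlorophenyl)carbamoyl group, stands within the scatter of compound 3. The expected step is small, a 1.1-fold lower number from compound 3 to compound 4 (0.05 log units; within the scatter). For compound 4 the estimated value is 4500 nM, with an expected range of 1800 nM to 9500 nM.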

Compound 4, half-maximal inhibitory concentration: 6400 nM
Compound 4: middle estimate off by 1.4-fold (0.15 log units), on the low side; measured number inside the range.
By their numbers in this assay, from the lowest: compounds 3, 1, 4 and 2 (each within the scatter of the next).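

In this assay, all three single changes now have a size: the (3,5-dichlorophenyl)carbamoyl group on the amine nitrogen gives a 1.3-fold higher number from compound 3 to compound 4 (0.10 log units; within the scatter), 3,4-dihydroxyphenyl in place of 3,4-dimethoxyphenyl gives a 1.4-fold lower number from compound 2 to compound 4 (0.15 log units; within the scatter), and isopropyl in place of hydrogen gives a 1.0-fold higher number from compound 1 to compound 4 (0.01 log units; within the scatter). All three steps lie within the scatter, so none of these changes separates the compounds in this assay. No evidence bearing on this result is available.

The compounds shown leave open whether a group without an aromatic ring, such as acetyl or a longer alkyl chain, on this amine nitrogen would give a step beyond the scatter. They also leave open whether a carboxylic acid in place of the isopropyl would do so.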